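Trimming one carbon from the unsaturated chain

The source may hold more compounds than are shown below. What is called first, only, known or untested is meant among the compounds shown, and "the series" means these compounds.

Of the compounds shown here, three have so far been measured in a functional assay on KYSE-450 cells (Homo sapiens) for inhibition, read by MTT assay, with a stated time of 48 h; a higher number here means a weaker inhibitor, a lower number a stronger inhibitor. Compound 1 (`CCCCC(=O)N(Cc1ccc(OC)c(O)c1)c1cc(OC)c(OC)c(OC)c1`) gives 300 nM there, compound 2 (`C/C=C/C(=O)N(Cc1ccc(OC)c(OC)c1)c1cc(OC)c(OC)c(OC)c1`) gives 39100 nM, and compound 3 (`CC/C=C/C(=O)N(Cc1ccc(OC)c(O)c1)c1cc(OC)c(OC)c(OC)c1`) gives 72 nM and so has the lowest number of the three, with both gaps beyond the scatter. That makes compound 3 the strongest inhibitor so far.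

Compound 4 (`C/C=C/C(=O)N(Cc1ccc(OC)c(O)c1)c1cc(OC)c(OC)c(OC)c1`) differs from compound 3 in one place (hydrogen in place of methyl on a saturated chain carbon bound to a double-bonded chain carbon): hydrogen in place of methyl on a saturated chain carbon bound to a double-bonded chain carbon, so but-1-en-1-yl becomes prop-1-en-1-yl.

Among the compounds with values here, only one measured step concerns this chain, and it is a different kind of change. The modest step of a 4.2-fold lower number from compound 1 to compound 3 (0.62 log units; beyond the scatter) came with but-1-en-1-yl in place of butyl on a carbonyl carbon, and it says little about losing a methyl. Compound 2 carries the prop-1-en-1-yl chain too, but it has methoxy where compound 4 has hydroxyl, so it is no direct guide.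

Within the data shown here, with no measured precedent for this change, only a small expected rise, not beyond the scatter, seems justified (a 1.4-fold higher number from compound 3 to compound 4 (0.14 log units; within the scatter)). In this assay the estimate for compound 4 is 100 nM as the middle value (expected range 25 nM to 450 nM).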

Compound 4, half-maximal inhibitory concentration: 67 nM
Beside the measured number, compound 4's estimate is 1.5-fold (0.17 log units) above it, and the stated range covers the measured number.
By their numbers in this assay, from the lowest: compounds 4 and 3 (each within the scatter of the next); then compound 1; then compound 2.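

Shortening the chain from but-1-en-1-yl to prop-1-en-1-yl, with ethyl becoming methyl, gives a 1.1-fold lower number from compound 3 to compound 4 (0.03 log units; within the scatter) in this assay, so this assay does not tell the two chains apart. Within the data shown here, compound 4 also gives the first matched reading of the oxygen on the aromatic ring with the prop-1-en-1-yl chain held fixed, with a 580-fold lower number from compound 2 to compound 4 (2.77 log units; beyond the scatter) for hydrogen in place of methyl, so this one small swap separates two compounds far more than the chain change does. Prop-1-en-1-yl in place of butyl gives a 4.5-fold lower number from compound 1 to compound 4 (0.65 log units; beyond the scatter), which sits on the same side as a 4.2-fold lower number from compound 1 to compound 3 (0.62 log units; beyond the scatter), so both unsaturated chains give lower numbers than butyl, and no measurement on hand explains any of these steps.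

On these data alone, what a saturated propyl chain on the carbonyl carbon would give remains open, so the part played by the double bond at this shorter length cannot be separated from that of chain length. As far as these compounds go, it is equally open whether a longer unsaturated chain, or an amine in place of the hydroxyl on the aromatic ring, would keep the number near that of compound 4.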